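The source may report more compounds than this note shows. Statements on the series, on what has been measured and on what is new or still open speak of the compounds shown alone.

Compound 3, `COc1cc(/C=C/C(=O)C2=C(/C=C/c3ccc(O)c(OC)c3)NC(=S)NC2c2ccccc2)ccc1O`, stands second highest of the three numbers measured in a functional assay, with a stated time of 20 min, tested at 50 uM; a lower number here means a weaker effect, a higher number a stronger effect of the compound at the concentration tested: compound 3 gives 50.4%, while compound 2, `COc1cc(/C=C/C(=O)C2=C(/C=C/c3ccc(O)c(OC)c3)NC(=O)NC2c2cccc([N+](=O)[O-])c2)ccc1O`, gives 48%, and compound 1, `COc1cc(/C=C/C(=O)C2=C(/C=C/c3ccc(O)c(OC)c3)NC(=O)NC2c2ccc(N(C)C)cc2)ccc1O`, gives 89.2%. The gap from compound 3 to compound 2 is within the scatter; the gap to compound 1 is beyond it.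

Compound 4, `COc1cc(/C=C/C(=O)C2=C(/C=C/c3ccc(O)c(OC)c3)NC(=S)NC2c2ccc(N(C)C)cc2)ccc1O`, differs from compound 3 in one place: dimethylamino in place of hydrogen on an aromatic carbon.

Among the measured compounds shown here, no measured step covers this exact change. For the measured compounds named here, the only step that bears on it is a number 41.2 percentage points lower from compound 1 to compound 2 (beyond the scatter), where the aryl group on the saturated ring carbon was exchanged with a large loss. Going by the values given here, compound 1, which carries the dimethylamino group on that aryl, has the highest number of the series, and compound 3, which carries no substituent there, sits far lower, though the two also differ elsewhere and no step between them is available.

On that basis a rise beyond the scatter is expected, a number 25.6 percentage points higher from compound 3 to compound 4 (beyond the scatter); compound 4 is estimated at 76%, within 55% to 92%.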

Compound 4, a percentage reported as activity, at one concentration (the size of the read-out at that concentration, not a potency): 84%
Compound 4: the middle estimate sits 8 percentage points below what was measured, and the stated range covers the measured number.
By their numbers in this assay, from the lowest: compounds 2 and 3 (each within the scatter of the next); then compounds 4 and 1 (each within the scatter of the next).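

In this assay, the change from phenyl to 4-(dimethylamino)phenyl now has a direct step of its own, on an aromatic carbon para to a large group: a number 33.6 percentage points higher from compound 3 to compound 4 (beyond the scatter). The dimethylamino group therefore carries a large gain on its own in the thiocarbonyl compounds, a link that earlier rested only on an exchange of two different substituted aryl groups. Compound 4 gives 84% and compound 1 gives 89.2%, values within the scatter of each other, so with dimethylamino in place the thiocarbonyl and carbonyl forms cannot be told apart here, and no measurement offered explains the gain.

Open, from the compounds shown here alone, is whether a primary amine, methylamino or methoxy at this place would match dimethylamino. Also open, going by these compounds, is how 3-nitrophenyl reads in the thiocarbonyl form.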